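The compounds below may be only part of what the source reports. "The series", "measured", "known", "first", "only" and "open" are said of these compounds alone.

Among the measured compounds shown here, the series shares one core, and the three measured members differ only in the groups on its two oxygen positions. Compound 1 `C=C1CC[C@@H]2[C@](C)(CO[Si](C)(C)C(C)(C)C)[C@H](O)CC[C@@]2(C)[C@@H]1C/C=C1/C(=O)OC[C@H]1OC(C)=O` gives 1.03 uM in a functional assay on P388 cells (Mus musculus) for cytotoxicity, read by sulforhodamine B assay; on this read-out higher numbers stand for an effect only at larger amounts of compound and lower numbers for an effect already at smaller amounts. Compound 2 `C=C1CC[C@@H]2[C@](C)(CO[Si](C)(C)C(C)(C)C)[C@H](O)CC[C@@]2(C)[C@@H]1C/C=C1/C(=O)OC[C@H]1O` gives 8.39 uM in this assay, and the step of an 8.1-fold higher number from compound 1 to compound 2 (0.91 log units; beyond the scatter). Compound 3 `C=C1CC[C@@H]2[C@](C)(CO[Si](C(C)C)(C(C)C)C(C)C)[C@H](O)CC[C@@]2(C)[C@@H]1C/C=C1/C(=O)OC[C@H]1O` gives 0.88 uM; the step of a 9.5-fold lower number from compound 2 to compound 3 (0.98 log units; beyond the scatter). Compound 3 thus has the lowest number of the three, though its gap to compound 1 lies within the scatter, so no order between those two can be claimed; only compound 2 stands clearly apart.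

Compound 4 `C=C1CC[C@@H]2[C@](C)(COC(C)=O)[C@H](O)CC[C@@]2(C)[C@@H]1C/C=C1/C(=O)OC[C@H]1O` is not yet measured. Relative to compound 3 the change is a group of 3 heavy atoms (2 carbon, 1 oxygen; no ring) in place of a group of 10 heavy atoms (9 carbon, 1 silicon; no ring), on an oxygen on a saturated carbon. The step of a 9.5-fold lower number from compound 2 to compound 3 (0.98 log units; beyond the scatter) shows that an exchange at this same oxygen can move the number beyond the scatter, while the step of an 8.1-fold higher number from compound 1 to compound 2 (0.91 log units; beyond the scatter) concerns the other oxygen and bears only indirectly. With the silicon-containing group gone entirely and an acetyl in its place, the number for compound 4 is expected to rise well beyond the scatter, a 9.1-fold higher number from compound 3 to compound 4 (0.96 log units; beyond the scatter), and compound 4 is estimated at 8 uM, within a range from 2 uM to 30 uM.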

Compound 4, concentration for half-maximal effect: 2.04 uM
Compound 4: the middle estimate sits 3.9-fold (0.59 log units) above what was measured; the range from low to high includes it.
By their numbers in this assay, from the lowest: compounds 3, 1 and 4 (each within the scatter of the next, the first and the last beyond it); then compound 2.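

With an acetyl on this oxygen, the number in this assay does not return to the level of the group of 7 heavy atoms (a 4.1-fold lower number from compound 2 to compound 4 (0.61 log units; beyond the scatter)), yet it also stays apart from that of the group of 10 heavy atoms (a 2.3-fold higher number from compound 3 to compound 4 (0.37 log units; beyond the scatter)). Compounds 2, 3 and 4 therefore separate into three distinct levels through this one oxygen, and the order does not follow the count of heavy atoms, since the smallest of the three groups gives the middle number; silicon in this group is also not needed for a number lower than that of compound 2. No measurement offered here explains why these three groups rank as they do.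

The compounds shown leave open what a free hydroxyl on this oxygen, or a longer acyl chain such as butanoyl or a benzoyl group, would give in this series. They also leave open whether exchanging the hydroxyl on the other oxygen for an acetyl, which separates compound 2 from compound 1, would move the number in the same direction with an acetyl on this oxygen.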